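The source may report more compounds than this note shows. Statements on the series, on what has been measured and on what is new or still open speak of the compounds shown alone.

Values measured in a functional assay on HepG2 cells (Homo sapiens) for inhibition, read by MTT assay, with a stated time of 48 h (on this read-out higher numbers stand for weaker inhibition and lower numbers for stronger inhibition), are as follows.

Compound 1 `COc1cc(C(=O)/C=C/c2ccc(N(C)C)cc2)cc(OC)c1OC` gives 30000 nM
Compound 2 `COc1cc(C(=O)/C=C/c2ccc(F)cc2)cc(OC)c1OC` gives 22000 nM
Compound 3 `COc1cc(C(=O)/C=C/c2ccc(C)cc2)cc(OC)c1OC` gives 52000 nM

Compound 3 (52000 nM) stands at the upper end of this small set, together with compound 1. Compound 4 `COc1cc(C(=O)/C=C/c2ccc(C=O)cc2)cc(OC)c1OC` has not yet been measured and carries formyl in place of methyl on an aromatic carbon, para to a large group (formyl in place of methyl on an aromatic carbon).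

The measured compounds differ at this same place. The step of a 2.4-fold higher number from compound 2 to compound 3 (0.37 log units; beyond the scatter) is the only one beyond the scatter, and it is modest, while a 1.7-fold higher number from compound 1 to compound 3 (0.24 log units; within the scatter) and a 1.4-fold lower number from compound 1 to compound 2 (0.13 log units; within the scatter) both stay within it. Fluoro, methyl and dimethylamino thus span a narrow band, but no measured compound carries a formyl group, so the data offer no direct evidence for this change.

The expectation of a lower number rests only on compound 3 standing at 52000 nM at the upper end of that band. In this assay a small step is expected, no larger than the modest one seen so far, and the estimated step is a 1.7-fold lower number from compound 3 to compound 4 (0.24 log units; within the scatter) as a best guess. For compound 4 the estimated value is 30000 nM with an expected range from 12000 nM to 70000 nM in this measurement.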

Compound 4, half-maximal inhibitory concentration: > 100000 nM
Compound 4 gave a limit, no number; the forecaster's own chance of this, stated with the estimate: 5%; middle value at least 3.3-fold (0.52 log units) from the limit.
By their numbers in this assay, from the lowest: compounds 2, 1 and 3 (each within the scatter of the next, the first and the last beyond it). At a limit, above all of these: compound 4.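

In this assay, compound 4 gives a limit and not a number: the limit of > 100000 nM in this assay, at which 1 of the 4 values shown sits. Even so, the formyl group is the first change at this position on the aromatic carbon to show a clear separation from other groups, with an at least 4.5-fold higher number from compound 2 to compound 4 (0.65 log units; beyond the scatter) and an at least 3.3-fold higher number from compound 1 to compound 4 (0.52 log units; beyond the scatter), so compound 4 reads weaker than both the fluoro and the dimethylamino compounds, which themselves sit within the scatter of each other. The comparison with the methyl group of compound 3 is less firm: an at least 1.9-fold higher number from compound 3 to compound 4 (0.28 log units; that floor lies within the scatter) gives only a floor, so this series does not establish that formyl in place of methyl moves the read-out beyond the scatter, although the true step may be larger.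

The compounds shown leave open how far past the limit compound 4 lies, and so how large any of its three steps really is. They also leave open whether the loss follows the carbonyl itself, which a hydroxymethyl group, an acetyl group or a carboxylic acid at the same place on the shared core could help to tell.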